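The source may report more compounds than this note shows. Statements on the series, on what has been measured and on what is new or still open speak of the compounds shown alone.

Among the compounds with values here, in a toxicity assay on microsomes from liver (Homo sapiens) for metabolic stability, read by LC-MS, using NADPH, tested at 1 uM (a higher number here means faster removal of the compound, a lower number slower removal), compound 3 `Cc1nc(C)n(CC(=O)N2CCN(c3sc(C(F)(F)F)nc3-c3cnc(OC(C)C)nc3)C[C@H]2C)n1` gives 16 mL.min-1.g-1, the only actual number in this set. Compound 1 `CCOc1ncc(-c2nc(C(F)(F)F)sc2N2CCN(C(=O)Cn3nc(C)nc3C)[C@H](C)C2)cn1` reports only a limit, < 10 mL.min-1.g-1. Compound 2 `COc1ncc(-c2nc(C(F)(F)F)sc2N2CCN(C(=O)Cn3nc(C)nc3C)[C@H](C)C2)cn1` also reports only a limit, < 10 mL.min-1.g-1.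

The next change puts cyclobutyl in place of isopropyl on an oxygen on an aromatic ring, giving compound 4 `Cc1nc(C)n(CC(=O)N2CCN(c3sc(C(F)(F)F)nc3-c3cnc(OC4CCC4)nc3)C[C@H]2C)n1`: cyclobutyl in place of isopropyl on an oxygen on an aromatic ring. The measured steps that bear on it alter the same alkoxy position: an at least 1.6-fold higher number from compound 2 to compound 3 (0.20 log units; that floor lies within the scatter), and an at least 1.6-fold higher number from compound 1 to compound 3 (0.20 log units; that floor lies within the scatter). Neither step is shown to exceed the scatter, and both rest on limits, so they fix no trend and give no true step size.

With an at least 1.6-fold higher number from compound 2 to compound 3 (0.20 log units; that floor lies within the scatter) as the closest guide, no step beyond the scatter is expected in this assay, with only a slight lean towards a higher number. The expected step is a 1.3-fold higher number from compound 3 to compound 4 (0.10 log units; within the scatter). The estimate for compound 4 is 20 mL.min-1.g-1, with an expected range of 10 mL.min-1.g-1 to 40 mL.min-1.g-1.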

Compound 4, intrinsic clearance in microsomes: 51 mL.min-1.g-1
For compound 4 the middle estimate is 2.6-fold (0.41 log units) below the measured one; the whole stated range lies below it.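

In this assay this position on the oxygen can now be seen to move the number beyond the scatter: cyclobutyl in place of isopropyl gives a 3.2-fold higher number from compound 3 to compound 4 (0.50 log units; beyond the scatter), whereas no earlier step was shown to exceed it. Cyclobutyl in place of the smaller groups also clears the scatter, with an at least 5.1-fold higher number from compound 2 to compound 4 (0.70 log units; beyond the scatter) and an at least 5.1-fold higher number from compound 1 to compound 4 (0.70 log units; beyond the scatter). These last two steps are floors and give no true size: the limit of < 10 mL.min-1.g-1 in this assay, at which 2 of the 4 values shown sit.

The compounds shown do not separate the effect of the four-membered ring from that of the added carbon on this oxygen. An open-chain butyl group would address that question, and a cyclopropyl or cyclopentyl group would show whether the number tracks ring size.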